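A Diacid Side Chain on the Amide Nitrogen

This account rests on a few compounds, and the source may have more. Where it says the series, first, only, none or still open, it means among the compounds named here.

Of the compounds shown here, three sharing one core have been tested in a functional assay on MCF7 cells (Homo sapiens) for antiproliferative activity, read by MTT assay, with a stated time of 24 h; a lower number here means a stronger inhibitor, a higher number a weaker inhibitor. Compound 1 `CCn1c(C(=O)NCCC(=O)OC)ccc1C(CC)(CC)c1ccc(OCS(=O)(=O)c2ccccc2)c(C)c1` carries a methoxycarbonyl group on the amide side chain. In this assay compound 1 gives only a limit, > 50000 nM. Compound 2 `CCn1c(C(=O)N[C@@H](C)CO)ccc1C(CC)(CC)c1ccc(OCS(=O)(=O)c2ccccc2)c(C)c1` gives 10800 nM, and compound 3 `CCn1c(C(=O)NCCO)ccc1C(CC)(CC)c1ccc(OCS(=O)(=O)c2ccccc2)c(C)c1` gives 15500 nM. The step of a 1.4-fold higher number from compound 2 to compound 3 (0.16 log units; within the scatter) lies within the scatter, so neither of these two can be called the stronger; compound 2 is simply the starting point followed here. The steps of an at least 4.6-fold lower number from compound 1 to compound 2 (0.66 log units; beyond the scatter) and an at least 3.2-fold lower number from compound 1 to compound 3 (0.50 log units; beyond the scatter) both show that replacing the ester with a hydroxy-bearing chain lowers the number at least modestly.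

Compound 4 `CCn1c(C(=O)N[C@@H](CCC(=O)O)C(=O)O)ccc1C(CC)(CC)c1ccc(OCS(=O)(=O)c2ccccc2)c(C)c1` differs from compound 2 by 1,3-dicarboxypropyl in place of 1-(hydroxymethyl)ethyl on an amide-type nitrogen. For the measured compounds named here, no measured step covers carboxylic acids on this chain; the only hint is that the ester compound 1 sat at a limit (the limit of > 50000 nM in this assay, at which 1 of the 3 values shown sits). Compound 4 is therefore expected to give a higher number, a step of a 2.8-fold higher number from compound 2 to compound 4 (0.44 log units; beyond the scatter), with a real chance that only a limit is reported. The estimate for compound 4 is 30000 nM, between 8000 nM and 120000 nM.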

Compound 4, half-maximal inhibitory concentration: > 50000 nM
Compound 4: a limit, no number; the forecaster's own chance of this, stated with the estimate: 40%; middle value at least 1.6-fold (0.22 log units) away from the limit.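

Compound 4 shows that this position on the amide nitrogen does not accept just any oxygen-bearing chain: in this assay, 1,3-dicarboxypropyl raises the number well beyond the scatter compared with either hydroxy-bearing chain (an at least 4.6-fold higher number from compound 2 to compound 4 (0.66 log units; beyond the scatter) and an at least 3.2-fold higher number from compound 3 to compound 4 (0.50 log units; beyond the scatter)). Compound 4 gives only a limit, so both steps are minimum sizes, and the step between compound 1 and compound 4 cannot be read. Among these four compounds, only the two hydroxy-bearing chains give a true number, while the ester and the diacid both end at the limit: the limit of > 50000 nM in this assay, at which 2 of the 4 values shown sit.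

On these data alone, it remains open whether a single carboxylic acid on the chain would behave like the diacid or like the hydroxy-bearing chains. An amine or a longer hydroxyalkyl chain at this position is also untested among the compounds shown.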